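The source may report more compounds than this note shows. Statements on the series, on what has been measured and on what is new or still open speak of the compounds shown alone.

Working notes on the series

Compound 2 `O=C(NC1CCNCC1)N1CCC(c2nc(-c3ccc4ccccc4n3)no2)CC1` carries a piperidin-4-yl urea on a piperidine-linked core. In a functional assay on Shh Light II cells (Mus musculus) for inhibition, read by a luciferase reporter (on this read-out higher numbers stand for weaker inhibition and lower numbers for stronger inhibition), compound 2 gives 2500 nM. Compound 3 `COc1ccccc1NC(=O)N1CCC(c2noc(-c3ccc4ccccc4n3)n2)CC1` gives 2400 nM in this assay, a value indistinguishable from that of compound 2 within the usual scatter. Compound 1 `O=C(Nc1ccccc1Cl)N1CCN(c2nc(-c3ccc4ccccc4n3)no2)CC1`, with a chlorophenyl urea on a piperazine attachment, gives 140 nM in this assay, a number well below that of compound 2, and the gap lies beyond the scatter. Compound 2 therefore stands at the high end of the three numbers shown, with compound 3 alongside it and compound 1 clearly apart.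

Compound 4 `O=C(NC1CCOCC1)N1CCC(c2nc(-c3ccc4ccccc4n3)no2)CC1` is not yet measured. It differs from compound 2 in one place: oxan-4-yl in place of piperidin-4-yl on an amide-type nitrogen. The piperidin-4-yl group that leaves holds one hydrogen-bond donor, the oxan-4-yl group that enters holds none; the acceptor count is unchanged. Among the measured compounds shown here, no measured pair isolates this change, so there is no step to lean on.

The expectation is a small move in this assay, likely toward a weaker number but not clearly beyond the scatter, so that the estimated step from compound 2 to compound 4 is a 1.2-fold higher number from compound 2 to compound 4 (0.08 log units; within the scatter). Compound 4 is estimated at 3000 nM, with a range from 1000 nM to 9000 nM.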

Compound 4, half-maximal inhibitory concentration: 480 nM
Beside the measured number, compound 4's estimate is 6.3-fold (0.80 log units) above it; measured number below the stated range.
By their numbers in this assay, from the lowest: compound 1; then compound 4; then compounds 3 and 2 (each within the scatter of the next).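

Oxan-4-yl in place of piperidin-4-yl on an amide-type nitrogen gives the first step in the series that can be read at a single place: in this assay there is a 5.2-fold lower number from compound 2 to compound 4 (0.72 log units; beyond the scatter) and this shows that the position is sensitive to the group it carries. The two groups match in heavy atoms and in ring size, with the ring nitrogen of piperidin-4-yl exchanged for the ring oxygen of oxan-4-yl and with the hydrogen-bond donor of the leaving group absent from the entering one, so an exchange this small is enough to move the number beyond the scatter. No supporting measurement bears on why the number moves, and this single pair does not separate the loss of the donor from the exchange of ring atom.

On these data alone, whether a ring hetero atom is needed here at all stays open, as does the outcome with the ring nitrogen kept but its hydrogen replaced; cyclohexyl and 1-methylpiperidin-4-yl on the same nitrogen would address these two points. Compounds 1 and 3 differ from compound 4 in more than one place, so whether the step carries over to their frameworks cannot be read.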